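Relocating one methoxy group: expectation for compound 4

A few compounds are considered here, and "the series" means these few. Any claim that something is new, unique, unknown or untested is made for them only; others in the source may bear on it.

Compound 1 `COc1cc(-c2nc3cc(/C=C4\SC(=O)N(CC(=O)N5CCOCC5)C4=O)ccc3[nH]2)cc(OC)c1OC` gives 18800 nM in an ADME assay on HEK-293T cells (Homo sapiens) for inhibition, read by MTT assay, with a stated time of 48 h; a higher number here means a weaker inhibitor, a lower number a stronger inhibitor. Compound 2 `COc1cc(OC)c(-c2nc3cc(/C=C4\SC(=O)N(CC(=O)N5CCOCC5)C4=O)ccc3[nH]2)cc1OC` gives 35700 nM in this assay; the change is 2,4,5-trimethoxyphenyl in place of 3,4,5-trimethoxyphenyl on an aromatic carbon, and the step is a 1.9-fold higher number from compound 1 to compound 2 (0.28 log units; within the scatter). Compound 3 `COc1cc(-c2nc3cc(/C=C4\SC(=O)N(CC(=O)N5CCCCC5)C4=O)ccc3[nH]2)cc(OC)c1OC` gives 21500 nM in this assay; its core differs from that of compound 1 by piperidin-1-yl in place of morpholin-4-yl on a carbonyl carbon, with the step of a 1.1-fold higher number from compound 1 to compound 3 (0.06 log units; within the scatter).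

Compound 4 `COc1cc(OC)c(-c2nc3cc(/C=C4\SC(=O)N(CC(=O)N5CCCCC5)C4=O)ccc3[nH]2)cc1OC` is not yet measured. It differs from compound 3 by 2,4,5-trimethoxyphenyl in place of 3,4,5-trimethoxyphenyl on an aromatic carbon, the same change as from compound 1 to compound 2, at the same place. The step of a 1.8-fold higher number from compound 3 to compound 4 (0.25 log units; within the scatter) is expected to match the earlier one because a 1.9-fold higher number from compound 1 to compound 2 (0.28 log units; within the scatter) lies within the scatter. Nothing here suggests the core of compound 3 would alter that. Compound 4 is therefore estimated at 38000 nM in this assay, with an expected range from 19000 nM to 76000 nM.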

Compound 4, half-maximal inhibitory concentration: > 50000 nM
Compound 4: a limit, no number (the forecaster's own chance of this, stated with the estimate: 10%); middle value at least 1.3-fold (0.11 log units) from the limit.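

Compound 4 gives > 50000 nM in this assay, which is a limit of the assay and not a number. On the core of compound 3, 2,4,5-trimethoxyphenyl in place of 3,4,5-trimethoxyphenyl gives an at least 2.3-fold higher number from compound 3 to compound 4 (0.36 log units; beyond the scatter), so the change carries over in the same direction, but this does not show whether its size is the same on both cores: the same change on two cores in this assay, a 1.9-fold higher number (0.28 log units; within the scatter) from compound 1 to compound 2 and an at least 2.3-fold higher number (0.36 log units; beyond the scatter) from compound 3 to compound 4; the limit leaves it open whether they differ Piperidin-1-yl in place of morpholin-4-yl, carried to the 2,4,5-trimethoxyphenyl compounds, gives an at least 1.4-fold higher number from compound 2 to compound 4 (0.14 log units; that floor lies within the scatter), and this does not show a dependence on the aryl group: the same change on two cores in this assay, a 1.1-fold higher number (0.06 log units; within the scatter) from compound 1 to compound 3 and an at least 1.4-fold higher number (0.14 log units; that floor lies within the scatter) from compound 2 to compound 4; the limit leaves it open whether they differ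

Still open, from the compounds shown here alone, is how either change would read with an open-chain amine such as diethylamine on the carbonyl carbon. Also open, going by these compounds, is how it would read with a phenyl bearing a single methoxy group on the shared core.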